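Azole swap on the chlorophenyl arm: oxazole to pyrazole

This account rests on a few compounds, and the source may have more. Where it says the series, first, only, none or still open, it means among the compounds named here.

Measured compounds:
- compound 1, `Cn1nc2c(=O)n(CC3(O)CCN(Cc4ccc(-n5ccnc5)cc4Cl)CC3)cnc2c1-c1ccc(CN)cc1`: 228 nM
- compound 2, `Cn1nc2c(=O)n(CC3(O)CCN(Cc4ccc(-c5ncco5)cc4Cl)CC3)cnc2c1-c1ccc(CN)cc1`: 1120 nM

Among the measured compounds shown here, in an assay on isolated protein for inhibition of ubiquitin carboxyl-terminal hydrolase 7 (Homo sapiens), with stated times of 30 min and 2 h (on this read-out higher numbers stand for weaker inhibition and lower numbers for stronger inhibition), compound 2 gives the highest of the two numbers measured; the only neighbour is compound 1, and the step of a 4.9-fold higher number from compound 1 to compound 2 (0.69 log units; beyond the scatter) lies beyond the scatter, so compound 2 is the weaker of the pair.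

Compound 3, `Cn1nc2c(=O)n(CC3(O)CCN(Cc4ccc(-n5cccn5)cc4Cl)CC3)cnc2c1-c1ccc(CN)cc1`, has not been measured. It differs from compound 2 in one place: 1H-pyrazol-1-yl in place of 1,3-oxazol-2-yl on an aromatic carbon. Both the leaving and the entering group are a five-membered aromatic ring with 2 hetero atoms and 2 hydrogen-bond acceptors, so the counted features of the substituent are unchanged.

For the measured compounds named here, the one measured step that bears on this position is a 4.9-fold higher number from compound 1 to compound 2 (0.69 log units; beyond the scatter), where an azole swap at the same aromatic carbon moved the number by a modest but real amount. A further azole swap is therefore expected to move this assay by a comparable size, and since the earlier swap weakened inhibition, a return in the other direction is the more likely outcome; the estimated step is a 2.8-fold lower number from compound 2 to compound 3 (0.45 log units; beyond the scatter). For compound 3 the expected value in this assay is 400 nM, with a range of 150 nM to 1100 nM.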

Compound 3, half-maximal inhibitory concentration: 233 nM
The estimate for compound 3 lay 1.7-fold (0.23 log units) above the measured number; low and high end bracket the measured number.
By their numbers in this assay, from the lowest: compounds 1 and 3 (each within the scatter of the next); then compound 2.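

In this assay, the step from 1,3-oxazol-2-yl to 1H-pyrazol-1-yl is a 4.8-fold lower number from compound 2 to compound 3 (0.68 log units; beyond the scatter), so this position separates two azoles that match in every feature counted for the substituent, including heavy atoms, hetero atoms and hydrogen-bond acceptors. The 1H-pyrazol-1-yl and 1H-imidazol-1-yl groups cannot be told apart on this read-out, with a 1.0-fold higher number from compound 1 to compound 3 (0.01 log units; within the scatter); among these three compounds, the two azoles joined to the aromatic carbon through a ring nitrogen therefore sit together, and the 1,3-oxazol-2-yl group, joined through a ring carbon, stands apart. Among the compounds shown here, with only three compounds, this is an observation on the series rather than a rule, and nothing available here accounts for the difference between the azoles.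

Still open, on these data alone, is whether the mode of attachment or the identity of the ring atoms governs the result: a 1,3-thiazol-2-yl group would test the first, and a 1H-1,2,4-triazol-1-yl group would test whether the match between compound 1 and compound 3 extends to a third ring nitrogen. The compounds also leave open how these azoles behave with a fluoro group in place of the chloro group.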